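The source may hold more compounds than are shown below. What is called first, only, known or untested is meant among the compounds shown, and "the series" means these compounds.

Of the compounds shown here, two built on the same core have so far been measured in a functional assay on HeLa cells (Homo sapiens) for inhibition, read by sulforhodamine B assay; on this read-out lower numbers stand for stronger inhibition and higher numbers for weaker inhibition. Compound 1 `O=C1C=C(Nc2ccc(Br)cc2)C(=O)c2c1nc1n2[C@H]2OC[C@@H](O)[C@H]2OC1` gives 3830 nM, the lowest of the two numbers. Within the data shown here, compound 2 `CCOc1ccccc1NC1=CC(=O)c2c(nc3n2[C@H]2OC[C@@H](O)[C@H]2OC3)C1=O` gives 8300 nM, a number that lies beyond the scatter above the one for compound 1. Compound 3 `O=C1C=C(Nc2cccc(Cl)c2)C(=O)c2c1nc1n2[C@H]2OC[C@@H](O)[C@H]2OC1` has not yet been tested in this assay. It differs from compound 1 in one place: 3-chlorophenyl in place of 4-bromophenyl on an amine nitrogen. Among the measured compounds shown here, no pair of measured compounds differing in a single place is available, so the effect of this kind of change cannot be read off the data; the only comparison at hand, between compound 1 and compound 2, involves a different group on the ring. The expected step is a 1.2-fold higher number from compound 1 to compound 3 (0.07 log units; within the scatter), which would stay within the scatter. Compound 3 is estimated at 4500 nM, with a range from 1500 nM to 13000 nM.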

Compound 3, half-maximal inhibitory concentration: 6040 nM
For compound 3 the middle estimate is 1.3-fold (0.13 log units) below the measured one; the measured number falls inside the stated range.
By their numbers in this assay, from the lowest: compounds 1, 3 and 2 (each within the scatter of the next, the first and the last beyond it).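

Within this assay this is the first comparison of two compounds that differ in only one place, and it reads as a 1.6-fold higher number from compound 1 to compound 3 (0.20 log units; within the scatter). On the amine nitrogen, then, 3-chlorophenyl can stand in place of 4-bromophenyl without the number leaving the usual scatter of repeated measurements, although the halogen and its place on the ring both change in this single step, so their separate contributions cannot be read. No measurement at hand offers an explanation for this result.

From the compounds shown here alone, whether a pyridine ring, a cyclohexyl group or a plain alkyl chain on that nitrogen would keep the number in the same range remains open. Also open, going by these compounds, is what an unsubstituted phenyl would give, which would show whether a halogen matters here at all.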